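The source may report more compounds than this note shows. Statements on the series, on what has been measured and on what is new or still open speak of the compounds shown alone.

Measured so far in an ADME assay on cells (Peritoneal macrophage, Mus musculus, strain BALB/c) for cytotoxicity, with a stated time of 72 h; on this read-out lower numbers stand for higher toxicity in this test and higher numbers for lower toxicity in this test:
compound 1, `Oc1ccccc1/C=N/Nc1ncccn1`, gives 84200 nM
compound 2, `Oc1ccc(O)c(/C=N/Nc2ncccn2)c1`, gives 89400 nM
compound 3, `O=C(N/N=C/c1ccccc1O)c1ncccn1`, gives only a limit, > 150000 nM

Compound 1 and compound 2 share a core and differ by hydroxy in place of hydrogen on an aromatic carbon, which gave a step of a 1.1-fold higher number from compound 1 to compound 2 (0.03 log units; within the scatter). Compound 3 has a different core; how it differs from compound 1 is not broken down here. Compound 3 sits at the limit of > 150000 nM in this assay, at which 1 of the 3 values shown sits.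

Compound 4, `O=C(N/N=C/c1cc(O)ccc1O)c1ncccn1`, has not yet been measured in this assay. It differs from compound 3 by hydroxy in place of hydrogen on an aromatic carbon. This is the same kind of change as that from compound 1 to compound 2, though the place differs in its description: meta to a large group here, against meta to a group of 9 heavy atoms there.

Because the step of a 1.1-fold higher number from compound 1 to compound 2 (0.03 log units; within the scatter) lies within the scatter, the corresponding step for compound 4 is expected to be small, a step that the limit leaves unreadable from compound 3 to compound 4. Compound 4 is therefore estimated at 200000 nM in this assay. The expected range for compound 4 runs from 100000 nM to 400000 nM. For compound 4 this assay is expected most likely to report only a limit again.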

Compound 4, half-maximal cytotoxic concentration: > 150000 nM
Compound 4 ended at the assay's limit; the forecaster's own chance of this, stated with the estimate: 70%; the middle value lies beyond the limit too.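

No step from compound 3 to compound 4 can be read, since both compounds end at a limit: the limit of > 150000 nM in this assay, at which 2 of the 4 values shown sit.

From the compounds shown here alone, whether hydroxy in place of hydrogen on an aromatic carbon changes the read-out in this pair stays open.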